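A few compounds are considered here, and "the series" means these few. Any claim that something is new, unique, unknown or untested is made for them only; others in the source may bear on it.

Measured in a functional assay on HUVEC cells (Homo sapiens) for inhibition; a higher number here means a weaker inhibitor, a lower number a stronger inhibitor:
compound 1 `COc1cc(/C=C/C(=O)c2cccc(NC(=O)c3ccc(Cl)c(Cl)c3)c2)ccc1O` gives 2.97 ug/mL
compound 2 `COC(=O)C(=O)Nc1cccc(C(=O)/C=C/c2ccc(O)c(OC)c2)c1` gives 1.5 ug/mL
compound 3 `CCOC(=O)C(=O)Nc1cccc(C(=O)/C=C/c2ccc(O)c(OC)c2)c1` gives 13.3 ug/mL

Compound 3 stands highest of the three numbers in this assay, with compound 1 nearest and compound 2 furthest. Compound 4 `COc1cc(/C=C/C(=O)c2cccc(NC(C)=O)c2)ccc1O` differs from compound 3 by methyl in place of ethoxycarbonyl on a carbonyl carbon. Among the measured compounds shown here, two measured steps bear on this change: an 8.9-fold higher number from compound 2 to compound 3 (0.95 log units; beyond the scatter) and a 4.5-fold higher number from compound 1 to compound 3 (0.65 log units; beyond the scatter). On this carbonyl carbon the smaller groups go with the lower numbers, and a 2.0-fold lower number from compound 1 to compound 2 (0.30 log units; within the scatter) does not go against that. Compound 4 carries the smallest group of the set at this place, so a lower number than compound 3 is expected, of a size near those steps; the expected step is a 5.3-fold lower number from compound 3 to compound 4 (0.73 log units; beyond the scatter). For compound 4 the estimate in this assay is 2.5 ug/mL, within 0.9 ug/mL to 7 ug/mL.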

Compound 4, half-maximal inhibitory concentration: 7.06 ug/mL
The estimate for compound 4 lay 2.8-fold (0.45 log units) below the measured number, and the stated range ends below it.
By their numbers in this assay, from the lowest: compounds 2 and 1 (each within the scatter of the next); then compounds 4 and 3 (each within the scatter of the next).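

In this assay the methyl group on this carbonyl carbon does not share the low numbers of the larger groups, with a 4.7-fold higher number from compound 2 to compound 4 (0.67 log units; beyond the scatter) and a 2.4-fold higher number from compound 1 to compound 4 (0.38 log units; beyond the scatter) as the steps. Size therefore does not order this place: a 1.9-fold lower number from compound 3 to compound 4 (0.28 log units; within the scatter) leaves methyl and ethoxycarbonyl unseparated, although they are the smallest and one of the larger groups here. Nothing available accounts for this.

Open, on these data alone, is how a carboxylic acid or an amine on this carbonyl carbon would read, and whether a longer chain on the ester oxygen would follow ethoxycarbonyl.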